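Bromo for chloro: what to expect of compound 4

The source may report more compounds than this note shows. Statements on the series, on what has been measured and on what is new or still open speak of the compounds shown alone.

In a functional assay on MGC-803 cells (Homo sapiens) for antiproliferative activity, read by MTT assay, with a stated time of 72 h (on this read-out higher numbers stand for weaker inhibition and lower numbers for stronger inhibition), compound 3 `O=C(N/N=C/c1cc(Cl)ccc1O)c1cccc(S(=O)(=O)N2CCOCC2)c1` gives 11000 nM. Compound 2 `COc1ccc(/C=N/NC(=O)c2cccc(S(=O)(=O)N3CCOCC3)c2)c(O)c1` gives 2070 nM, so compound 3 holds the higher of the two exact numbers, and the gap is a 5.3-fold higher number from compound 2 to compound 3 (0.73 log units; beyond the scatter). Compound 1 `O=C(N/N=C/c1ccco1)c1cccc(S(=O)(=O)N2CCOCC2)c1` reaches only a limit of the assay, > 100000 nM.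

Compound 4 `O=C(N/N=C/c1cc(Br)ccc1O)c1cccc(S(=O)(=O)N2CCOCC2)c1` differs from compound 3 by a single atom: bromo in place of chloro on an aromatic carbon. This is bromo in place of chloro on an aromatic carbon, para to a hydroxy group.

Within the data shown here, no measured step swaps one halogen for another. All three replace the whole group on the carbon with a double bond to nitrogen, a far larger change. They include an at least 48-fold lower number from compound 1 to compound 2 (1.68 log units; beyond the scatter), a large step, and an at least 9.0-fold lower number from compound 1 to compound 3 (0.95 log units; beyond the scatter), at least a modest one. Even the step between the two hydroxyphenyl groups, from compound 2 to compound 3, is only modest and changes more than one atom. These steps show that this part of the molecule matters, but they give no direction for a halogen exchange.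

The expected result is therefore a 1.1-fold lower number from compound 3 to compound 4 (0.04 log units; within the scatter), a step no larger than the scatter. The estimate for compound 4 is 10000 nM, within an expected range of 4000 nM to 30000 nM.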

Compound 4, half-maximal inhibitory concentration: 14800 nM
The estimate for compound 4 lay 1.5-fold (0.17 log units) below the measured number; low and high end bracket the measured number.
By their numbers in this assay, from the lowest: compound 2; then compounds 3 and 4 (each within the scatter of the next). At a limit, above all of these: compound 1.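

In this assay, among these compounds, this is the first exchange of one halogen for another at this position, on an aromatic carbon para to a hydroxy group, and it gives a step no larger than the scatter (a 1.3-fold higher number from compound 3 to compound 4 (0.13 log units; within the scatter)), so chloro and bromo cannot be told apart here on this read-out. Set against the other two groups on the carbon with a double bond to nitrogen, the 5-bromo-2-hydroxyphenyl group keeps the same standing that the 5-chloro-2-hydroxyphenyl group had, with compound 2 still holding the lower number (a 7.1-fold higher number from compound 2 to compound 4 (0.85 log units; beyond the scatter)) and compound 1 still far from both halogen compounds (an at least 6.7-fold lower number from compound 1 to compound 4 (0.82 log units; beyond the scatter)). Compound 1 stands at a limit and not at a number, so that last step gives only a bound: (the limit of > 100000 nM in this assay, at which 1 of the 4 values shown sits).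

With only chloro and bromo shown at this position, the effect of a fluoro, a methyl, a methoxy or an amine there remains open. Also open, from the compounds shown here alone, is whether a halogen and the methoxy group of compound 2 could work together on one ring, and whether the hydroxy group is needed at all.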